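The compounds below may be only part of what the source reports. "The series", "measured", "known", "first", "only" and "open" are said of these compounds alone.

Measured so far in a functional assay (Homo sapiens); on this read-out higher numbers stand for weaker inhibition and lower numbers for stronger inhibition:
compound 1 `C#Cc1cccc(-c2nccc3nc(N)nn23)c1` gives 12600 nM; 12600 nM (2 entries)
compound 2 `Nc1nc2ccnc(-c3cccc(OC(F)F)c3)n2n1` gives 3400 nM; 3400 nM (2 entries)
compound 3 `Nc1nc2ccnc(-c3cccc([N+](=O)[O-])c3)n2n1` gives 3800 nM

Compound 3 stands level with compound 2, as their two values lie within the usual scatter of each other. Compound 1 reads higher than both, which on this read-out means weaker inhibition. The next compound to be tested is compound 4 `Cc1cnc(-c2cccc([N+](=O)[O-])c2)n2nc(N)nc12`, which differs from compound 3 by methyl in place of hydrogen on an aromatic carbon. Among the compounds with values here, no two measured compounds differ in one place only, so the data hold no direct precedent for this change. Without such a precedent, no direction can be favoured, and no step beyond the scatter is expected in this assay on present evidence. The estimated change is a 1.1-fold lower number from compound 3 to compound 4 (0.04 log units; within the scatter) in this reading. For compound 4 the expected value is 3500 nM with an estimated range from 1000 nM to 12000 nM in this reading.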

Compound 4, half-maximal inhibitory concentration: 8700 nM
Compound 4: middle estimate off by 2.5-fold (0.40 log units), on the low side; low and high end bracket the measured number.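

In this assay, methyl in place of hydrogen on an aromatic carbon of the six-membered aromatic ring with 2 nitrogen gives a 2.3-fold higher number from compound 3 to compound 4 (0.36 log units; beyond the scatter). Within the data shown here, this is the first step here that changes one place only, and it shows that this carbon is not indifferent to substitution: a single added methyl moves the read-out beyond the scatter, toward weaker inhibition. Nothing available bears on the reason for this step.

Going by these compounds, whether the loss belongs to methyl in particular or to any group on this carbon remains open, as a fluorine atom, a methoxy group or an amine there might read differently. A single step also cannot tell whether methyl would act alike with the other groups carried by compound 1 and compound 2.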